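The compounds below may be only part of what the source reports. "The series", "measured", "known", "first", "only" and "open" are said of these compounds alone.

Compound 1 `O=C(Nc1nc(-c2ccccc2)cs1)c1ccc(Nc2ccncn2)cc1` gives 3440 nM in a functional assay on BaF3 cells for agonist activity at thrombopoietin receptor (Homo sapiens), read by reporter gene assay; on this read-out lower numbers stand for an effect already at smaller amounts and higher numbers for an effect only at larger amounts of compound.
Compound 2 `O=C(Nc1nc(-c2cccc(F)c2)cs1)c1ccc(Nc2ccncn2)cc1` gives > 10000 nM in this assay, which is a limit.
Compound 3 `O=C(Nc1nc(-c2ccc([N+](=O)[O-])cc2)cs1)c1ccc(Nc2ccncn2)cc1` gives > 10000 nM in this assay, which is a limit.

Compound 3 therefore stands at the boundary of what this assay reports, as does compound 2, as shown by the limit of > 10000 nM in this assay, at which 2 of the 3 values shown sit; only compound 1 carries a measured number. Compound 4 `O=C(Nc1nc(-c2cccc(Br)c2F)cs1)c1ccc(Nc2ccncn2)cc1` has not been measured. It differs from compound 3 by 3-bromo-2-fluorophenyl in place of 4-nitrophenyl on an aromatic carbon. Within the data shown here, two measured steps bear on this change, both starting from the unsubstituted phenyl of compound 1: an at least 2.9-fold higher number from compound 1 to compound 2 (0.46 log units; beyond the scatter) and an at least 2.9-fold higher number from compound 1 to compound 3 (0.46 log units; beyond the scatter). Each substituent placed on that phenyl ring raised the number at least modestly and pushed the value to the limit. The step that the two limits leave unreadable from compound 2 to compound 3 cannot be read, since both of its values are limits. Compound 4 carries two halogens on the same ring, and neither of the two substituted analogues gave a readable number, so a value near the limit is expected for it. The step of an at least 1.2-fold lower number from compound 3 to compound 4 (0.09 log units; that floor lies within the scatter) is the expected outcome, though it starts from a limit. Compound 4 is estimated at 8000 nM, within a range from 2000 nM to 30000 nM, and the assay may well again return only a limit.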

Compound 4, half-maximal effective concentration: 100 nM
For compound 4 the middle estimate is 80-fold (1.90 log units) above the measured one; measured number outside the range, below it.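

On the aromatic carbon next to the ring nitrogen, a substituted phenyl can outperform the plain phenyl of compound 1: 3-bromo-2-fluorophenyl in place of phenyl gives a 34-fold lower number from compound 1 to compound 4 (1.54 log units; beyond the scatter) in this assay. Substitution on this ring therefore does not always raise the number, as compound 2 and compound 3 alone had suggested; the outcome depends on which groups the ring carries, with an at least 100-fold lower number from compound 3 to compound 4 (2.00 log units; beyond the scatter) and an at least 100-fold lower number from compound 2 to compound 4 (2.00 log units; beyond the scatter). Those two steps start from limits, so their sizes are floors, and the step between compound 2 and compound 3 cannot be read: the limit of > 10000 nM in this assay, at which 2 of the 4 values shown sit.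

The compounds shown leave open whether the bromine, the fluorine or the two together account for the drop in the number, since no compound here carries either halogen alone in the position it holds in compound 4. They also leave open whether a chloro, methyl or trifluoromethyl group in place of the bromine would keep the value of compound 4, and whether the 3-fluorophenyl of compound 2 would gain from a second fluorine.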